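Chloro-bearing sulfonamide series: nitro to amino

The compounds below may be only part of what the source reports. "The series", "measured", "known", "first", "only" and "open" are said of these compounds alone.

Measured in a functional assay on MC-38 cells (Mus musculus) for antiproliferative activity, read by colorimetric assay and MTT assay; on this read-out higher numbers stand for weaker inhibition and lower numbers for stronger inhibition:
- compound 1 `O=S(=O)(Nc1cc(Cl)cc2cc[nH]c12)c1ccc(Cl)cc1`: 8.5 ug/mL
- compound 2 `O=[N+]([O-])c1ccc(S(=O)(=O)Nc2cccc3cc[nH]c23)cc1`: 7.2 ug/mL
- compound 3 `O=[N+]([O-])c1ccc(S(=O)(=O)Nc2cccc3c(Cl)c[nH]c23)cc1`: 0.34 ug/mL

Compound 3 has the lowest number of the three at 0.34 ug/mL, and its gaps to the other two lie beyond the scatter. The next structure is compound 4 `Nc1ccc(S(=O)(=O)Nc2cccc3c(Cl)c[nH]c23)cc1`, which carries amino in place of nitro on an aromatic carbon, para to a large group: amino in place of nitro on an aromatic carbon.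

For the measured compounds named here, only one measured step isolates a single change, a 21-fold lower number from compound 2 to compound 3 (1.33 log units; beyond the scatter). That step is large, but it concerns chloro in place of hydrogen at another place. Going by the values given here, no measured step replaces nitro, so the size of this change remains open. Compound 4 keeps the chloro of compound 3, which has 0.34 ug/mL, so its number is expected to stay near that value. In this assay, no step beyond the scatter is expected, and the direction is uncertain. The estimated change is a 1.5-fold higher number from compound 3 to compound 4 (0.17 log units; within the scatter). For compound 4 the expected value is 0.5 ug/mL, with an estimated range of 0.1 ug/mL to 2.5 ug/mL.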

Compound 4, half-maximal inhibitory concentration: 0.23 ug/mL
Compound 4: middle estimate off by 2.2-fold (0.34 log units), on the high side, and the stated range covers the measured number.
By their numbers in this assay, from the lowest: compounds 4 and 3 (each within the scatter of the next); then compounds 2 and 1 (each within the scatter of the next).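

In this assay, the first measured replacement of nitro, amino in place of nitro on an aromatic carbon, para to a large group, gives a 1.5-fold lower number from compound 3 to compound 4 (0.17 log units; within the scatter) and so leaves the read-out within the scatter with the chloro kept. At this place the series therefore accepts a change from 3 heavy atoms to 1 heavy atom and from 0 hydrogen-bond donors to 1 hydrogen-bond donor, with the loss of a double bond outside aromatic rings, without a step beyond the scatter. No measurement shown explains why the read-out holds across this change.

The compounds shown do not tell whether the large step seen on adding chloro to the nitro compound would also appear with amino at this place. On these data alone, how a carboxylic acid or a methoxy group would read here also remains open.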